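Cyclopentyl isoindolinone: swapping the carboxyphenyl arm

The source may report more compounds than this note shows. Statements on the series, on what has been measured and on what is new or still open speak of the compounds shown alone.

Measured compounds in an assay on HEK293 cells for positive allosteric modulation of metabotropic glutamate receptor 2 (Rattus norvegicus), read by thallium flux; a higher number here means that more compound is needed for the effect, a lower number that less compound is needed:
- compound 1, `O=C(O)c1cc(-c2cccc(COc3ccc4c(=O)n(C5CCC5)sc4c3)c2)ccc1Cl`: 580 nM
- compound 2, `COc1ccc(-c2cccc(COc3ccc4c(c3)CN(C3CCCC3)C4=O)c2)cc1C(=O)O`: 170 nM
- compound 3, `CC(C)Cn1sc2cc(OCc3cccc(-c4ccc(Cl)c(C(=O)O)c4)c3)ccc2c1=O`: 470 nM

Compound 2 gives the lowest of the three numbers. Its nearest neighbour is compound 3, which sits beyond the scatter above it, and compound 1 lies further still above it, also beyond the scatter. Compounds 1 and 3 share a core that differs from the core of compound 2, and they carry a chloro-carboxyphenyl arm rather than the methoxy-carboxyphenyl arm of compound 2.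

Compound 4, `O=C(O)c1ccc(Cl)c(-c2cccc(COc3ccc4c(c3)CN(C3CCCC3)C4=O)c2)c1`, has not yet been measured. It keeps the core of compound 2 and differs from it in one place: 5-carboxy-2-chlorophenyl in place of 3-carboxy-4-methoxyphenyl on an aromatic carbon.

Among the measured compounds shown here, the only measured step, a 1.2-fold lower number from compound 1 to compound 3 (0.09 log units; within the scatter), changes the group on the aromatic nitrogen of a different core and does not bear on the arm exchange. For the measured compounds named here, no pair of measured compounds isolates the change from compound 2 to compound 4, so the expectation rests only on the values themselves: compounds 1 and 3 with a chloro-carboxyphenyl arm give higher numbers than compound 2, but their core also differs, and the new arm of compound 4 is a different isomer. A modest rise is therefore expected, a 1.8-fold higher number from compound 2 to compound 4 (0.25 log units; within the scatter), with wide uncertainty. Compound 4 is estimated at 300 nM, within 120 nM to 800 nM.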

Compound 4, half-maximal effective concentration: 90 nM
Beside the measured number, compound 4's estimate is 3.3-fold (0.52 log units) above it; measured number outside the range, below it.
By their numbers in this assay, from the lowest: compounds 4 and 2 (each within the scatter of the next); then compounds 3 and 1 (each within the scatter of the next).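

In this assay, exchanging 3-carboxy-4-methoxyphenyl for 5-carboxy-2-chlorophenyl gives a 1.9-fold lower number from compound 2 to compound 4 (0.28 log units; within the scatter), so on this core the two arms cannot be told apart. Among the compounds shown here, this is the first comparison of two arms on one core, and it shows that this place on the ring, meta to a large group, accepts both arms, which differ in their substituent and in where it and the carboxylic acid stand, without a step beyond the scatter. The exchange alters the substituent and the substitution pattern together, so their separate contributions cannot be read from this single step, and nothing measured here accounts for the result.

The compounds shown leave open whether the carboxylic acid on this arm can give way to a tetrazole or a primary amide, and whether a fluorine, a methyl group or a hydrogen in place of the chlorine would keep the number within the scatter. They also leave open how the 5-carboxy-2-chlorophenyl arm would read on the core of compound 1.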